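The source may report more compounds than this note shows. Statements on the series, on what has been measured and on what is new or still open speak of the compounds shown alone.

Of the compounds shown here, three built on one shared core have been measured in an assay on Huh-7 cells for agonist activity at Bile acid receptor (Homo sapiens), read by a luciferase reporter; on this read-out higher numbers stand for an effect only at larger amounts of compound and lower numbers for an effect already at smaller amounts. Compound 1 `CC(C)c1onc(-c2c(Cl)cccc2Cl)c1COc1ccc(-c2nc3cc(C(=O)O)ccc3n2C)cc1` gives 25.8 nM. Compound 2 `CCCn1c(-c2ccc(OCc3c(-c4c(Cl)cccc4Cl)noc3C(C)C)cc2)nc2ccc(C(=O)O)cc21` gives 9.3 nM, and compound 3 `CC(C)c1onc(-c2c(Cl)cccc2Cl)c1COc1ccc(-c2nc3ccc(C(=O)O)cc3n2C)c(Cl)c1` gives 3.66 nM. Compound 2 therefore stands second highest of the three numbers: the gap to compound 3, its nearest neighbour, lies beyond the usual scatter, and so does the larger gap to compound 1.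

Compound 4 `CC(=O)N1CCC(n2c(-c3ccc(OCc4c(-c5c(Cl)cccc5Cl)noc4C(C)C)cc3)nc3ccc(C(=O)O)cc32)CC1` has not yet been measured in this assay. It differs from compound 2 in a single place: 1-acetylpiperidin-4-yl in place of propyl on an aromatic nitrogen. Within the data shown here, no pair of measured compounds shows a step of this kind, so nothing directly comparable is at hand and the expectation rests on compound 2 alone together with the narrow spread seen across compounds 1 to 3. A step from compound 2 to compound 4 of a 1.6-fold higher number from compound 2 to compound 4 (0.21 log units; within the scatter) is expected, that is, a small rise at most, likely inside the scatter. Compound 4 is accordingly estimated at 15 nM, with a range from 4 nM to 60 nM.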

Compound 4, half-maximal effective concentration: 1430 nM
For compound 4 the middle estimate is 95-fold (1.98 log units) below the measured one; the whole stated range lies below it.
By their numbers in this assay, from the lowest: compound 3; then compound 2; then compound 1; then compound 4.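

In this assay, among these compounds, this aromatic nitrogen proves to be a place where a single change counts heavily, which no earlier pair could show: 1-acetylpiperidin-4-yl in place of propyl gives a 150-fold higher number from compound 2 to compound 4 (2.19 log units; beyond the scatter) and this step lies well beyond the scatter. The entering group brings more heavy atoms, a six-membered non-aromatic ring and a hydrogen-bond acceptor all at once, with no net charge on either side, so this one step cannot separate these features. No measurement at hand bears on why the number rises so far.

A cyclohexyl group, a piperidin-4-yl carrying a free amine, or a longer alkyl chain such as butyl on this nitrogen would show whether the ring or the acetyl group goes with the rise. As far as these compounds go, whether the step keeps its size alongside the chlorine of compound 3 also remains open.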